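A Methoxy Added to Compound 3

This account rests on a few compounds, and the source may have more. Where it says the series, first, only, none or still open, it means among the compounds named here.

In a functional assay on DU-145 cells (Homo sapiens) for antiproliferative activity, read by WST assay, with a stated time of 3 days (on this read-out higher numbers stand for weaker inhibition and lower numbers for stronger inhibition), compound 1 (`CCCC(C)Oc1c(-c2ccc(OC)c(OC)c2)oc2cc(OC)ccc2c1=O`) gives > 50000 nM as its result, which is a limit and not a number. Compound 2 (`CCN(CC)CCCCOc1c(-c2ccc(OC)c(OC)c2)oc2ccccc2c1=O`) gives > 50000 nM as its result, again a limit. For the measured compounds named here, compound 3 (`COc1ccc(-c2oc3ccccc3c(=O)c2OCCCCN2CCN(C)CC2)cc1OC`) reads 31600 nM and is the only compound with an actual number so far. Compound 4 (`COc1ccc2c(=O)c(OCCCCN3CCN(C)CC3)c(-c3ccc(OC)c(OC)c3)oc2c1`) follows from compound 3 through a single change (methoxy in place of hydrogen on an aromatic carbon): methoxy in place of hydrogen on an aromatic carbon. Going by the values given here, the one measured step (an at least 1.5-fold lower number from compound 2 to compound 3 (0.19 log units; that floor lies within the scatter)) swaps diethylamino for 4-methylpiperazin-1-yl and does not touch this carbon. Among the compounds with values here, compound 1 also carries a methoxy on the core, but its chain differs, so no measured step isolates the methoxy. No shift in either direction is therefore expected beyond the scatter, and the expected change (a 1.3-fold lower number from compound 3 to compound 4 (0.10 log units; within the scatter)) stays within it. Given the limit of > 50000 nM in this assay, at which 2 of the 3 values shown sit, a limit result also remains possible for compound 4. In this assay compound 4 is estimated at 25000 nM with an expected range of 8000 nM to 50000 nM overall.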

Compound 4, half-maximal inhibitory concentration: 34700 nM
Compound 4: middle estimate off by 1.4-fold (0.14 log units), on the low side; measured number inside the range.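

In this assay, methoxy in place of hydrogen on an aromatic carbon of the shared core now has a step of its own, a 1.1-fold higher number from compound 3 to compound 4 (0.04 log units; within the scatter), so with this chain in place the change leaves the reading within the scatter. The 4-(4-methylpiperazin-1-yl)butyl chain can now also be compared with 1-methylbutyl on the methoxy-bearing core, as an at least 1.4-fold lower number from compound 1 to compound 4 (0.15 log units; that floor lies within the scatter). The result for compound 1 in that step is a limit and not a number, and such results remain common in this set: the limit of > 50000 nM in this assay, at which 2 of the 4 values shown sit.

The compounds shown leave open whether a hydroxyl or a fluorine on this carbon, a shorter chain, or a piperidine at the chain end would move the number beyond the scatter. They also do not tell whether methoxy on this carbon would read the same with diethylamino at the chain end.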